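Amide nitrogen exchange: from compound 2 to compound 4

The source may report more compounds than this note shows. Statements on the series, on what has been measured and on what is new or still open speak of the compounds shown alone.

In a functional assay on A549 cells (Homo sapiens) for antiproliferative activity, read by CCK-8 assay, with a stated time of 48 h (on this read-out lower numbers stand for stronger inhibition and higher numbers for weaker inhibition), the three measured compounds stand as follows:

compound 1, `O=C(Nc1ccccc1)c1cc(Oc2ccc(/C=C/c3ccccn3)cc2)ccn1`: 19100 nM
compound 2, `O=C(Nc1ccc(Cl)cc1)c1cc(Oc2ccc(/C=C/c3ccccn3)cc2)ccn1`: 16200 nM
compound 3, `CC(C)NC(=O)c1cc(Oc2ccc(/C=C/c3ccccn3)cc2)ccn1`: 21400 nM

Compound 2 sits at one end of the three numbers, yet the step of a 1.2-fold lower number from compound 1 to compound 2 (0.07 log units; within the scatter) and the step of a 1.3-fold higher number from compound 2 to compound 3 (0.12 log units; within the scatter) both show that none of the three is set apart from the others. The step from compound 1 to compound 3, a 1.1-fold higher number from compound 1 to compound 3 (0.05 log units; within the scatter), is likewise within the scatter.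

Compound 4, `O=C(NC1CCCCC1)c1cc(Oc2ccc(/C=C/c3ccccn3)cc2)ccn1`, has not been measured in this assay. It differs from compound 2 as cyclohexyl in place of 4-chlorophenyl on an amide-type nitrogen. Within the data shown here, the step that bears most directly on it is the one from compound 2 to compound 3, where a non-aromatic group likewise replaced 4-chlorophenyl on the amide-type nitrogen and the number hardly moved. The step from compound 1 to compound 3 tells the same story for a non-aromatic group in place of phenyl. On this basis, no step beyond the scatter is expected in this assay for compound 4: the change from compound 2 to compound 4 is estimated at a 1.1-fold higher number from compound 2 to compound 4 (0.05 log units; within the scatter).

Compound 4 is therefore expected to give 18000 nM in this assay, with a range from 9000 nM to 36000 nM.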

Compound 4, half-maximal inhibitory concentration: 12500 nM
The estimate for compound 4 lay 1.4-fold (0.16 log units) above the measured number, within the range that was stated.
By their numbers in this assay, from the lowest: compounds 4, 2, 1 and 3 (each within the scatter of the next).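

Notes on the amide-type nitrogen, read in this assay: cyclohexyl in place of 4-chlorophenyl gives a 1.3-fold lower number from compound 2 to compound 4 (0.11 log units; within the scatter) and so adds a non-aromatic ring of carbon only to a position where, until now, only two aromatic rings and the open isopropyl group had been seen. Among these compounds, the same ring in place of phenyl gives a 1.5-fold lower number from compound 1 to compound 4 (0.18 log units; within the scatter) and in place of isopropyl gives a 1.7-fold lower number from compound 3 to compound 4 (0.23 log units; within the scatter) so that phenyl, 4-chlorophenyl, isopropyl and cyclohexyl now all sit within the scatter of one another, with no step at this position leaving it, whether the ring is aromatic or not and whether the group is a ring or an open one. Nothing at hand explains why this position responds so little.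

The compounds shown leave open whether any group on this nitrogen can move the number beyond the scatter, for example a longer chain ending in an amine or in a carboxylic acid. They also leave open whether a change elsewhere on the shared core would do so, since all four compounds carry the same core.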